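The source may hold more compounds than are shown below. What is called first, only, known or untested is meant among the compounds shown, and "the series" means these compounds.

In a functional assay (Homo sapiens) for inhibition (on this read-out higher numbers stand for weaker inhibition and lower numbers for stronger inhibition), compound 1 `C/C(=C\COc1c(Cl)cccc1Cl)CC/C=C(\C)C1CC(=O)C(C)(C)O1` gives 50.5 ug/mL and compound 2 `C/C(=C\COc1c(Cl)cccc1Cl)CC/C=C(\C)C1=CC(=O)C(C)(C)O1` gives 27.4 ug/mL as its reading. These two values lie within the scatter of each other, so compound 2 stands level with compound 1 and not clearly apart from it. Compound 3 `C/C(=C\COc1ccccc1)CC/C=C(\C)C1=CC(=O)C(C)(C)O1` keeps everything in compound 2 except one group: phenyl in place of 2,6-dichlorophenyl on an oxygen on a saturated carbon. Going by the values given here, only one measured step exists, a 1.8-fold lower number from compound 1 to compound 2 (0.27 log units; within the scatter), and it stays within the scatter. That step lies in the shared core, not on the group that changes here, so it bears only indirectly on this change. Among the compounds with values here, no measured pair tests the removal of the 2,6-dichlorophenyl group. No step beyond the scatter is therefore expected in this assay, although the range must stay wide and a slight drift toward a higher number is allowed for. The expected step is a 1.3-fold higher number from compound 2 to compound 3 (0.11 log units; within the scatter) as a central estimate. For compound 3 the estimated value is 35 ug/mL, with an expected range from 14 ug/mL to 90 ug/mL as the likely bounds.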

Compound 3, half-maximal inhibitory concentration: 35.2 ug/mL
Compound 3: middle estimate off by 1.0-fold (0.00 log units), on the low side; the range from low to high includes it.
By their numbers in this assay, from the lowest: compounds 2, 3 and 1 (each within the scatter of the next).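

Going by these compounds alone, replacing 2,6-dichlorophenyl with phenyl on an oxygen on a saturated carbon gives, in this assay, a 1.3-fold higher number from compound 2 to compound 3 (0.11 log units; within the scatter), and this is the first reading on this position, since compound 1 and compound 2 differ only in the shared core. The group can therefore lose its chlorine atoms and shrink from 8 heavy atoms to 6 while compound 3 stays level with compound 2, so the chlorine atoms are not needed to hold the reading at this level in this assay. No evidence is at hand that could account for this result.

The compounds shown leave open whether any group on this oxygen can move the reading beyond the scatter, for example a pyridine ring, a methoxy-substituted phenyl, a carboxylic acid on the phenyl or a simple alkyl chain in place of the aromatic ring. They also leave open whether phenyl would read the same on the saturated ring of compound 1, and whether a nitrogen in place of the oxygen that carries the ring would change the reading.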